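The source may hold more compounds than are shown below. What is called first, only, known or untested is meant among the compounds shown, and "the series" means these compounds.

Compound 3 `CCC(C)C(C(=O)Nc1ccc(C(C)=O)cc1)N(C(=O)c1ccccc1)S(=O)(=O)c1ccccc1` is the weakest of the three measured compounds in a functional assay for inhibition, read by spectrophotometry, with a stated time of 20 min, tested at 2 mg/mL (on this read-out higher numbers stand for a stronger effect at the one concentration tested and lower numbers for a weaker effect), where compound 3 gives 11.4%. Compound 2 `CC(=O)c1ccc(NC(=O)C(CC(C)C)N(C(=O)c2ccccc2)S(=O)(=O)c2ccccc2)cc1` gives 33.7% in this assay, and compound 1 `CC(=O)c1ccc(NC(=O)C(C(C)C)N(C(=O)c2ccccc2)S(=O)(=O)c2ccc([N+](=O)[O-])cc2)cc1` gives 29.8%. Within the data shown here, the only measured step that changes a single place is a number 22.3 percentage points lower from compound 2 to compound 3 (beyond the scatter), so lengthening the branched chain to sec-butyl costs a modest but clear amount of inhibition.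

Compound 4 `CC(=O)c1ccc(NC(=O)C(C(C)C)N(C(=O)c2ccccc2)S(=O)(=O)c2ccccc2)cc1` differs from compound 3 by hydrogen in place of methyl on a saturated chain carbon, three bonds along the chain from an amide-type nitrogen and a carbonyl carbon, which returns the chain to isopropyl. The step from compound 2 to compound 3 is the only measured one touching this chain, and it points the other way from the change now considered: shortening the chain again is expected to undo most of that loss. Compound 1 carries the same isopropyl chain and differs from compound 4 elsewhere in the molecule, so its value gives a rough anchor for where an isopropyl member of the series sits.

For compound 4 a rise of a number 16.6 percentage points higher from compound 3 to compound 4 (beyond the scatter) in this assay is therefore expected, beyond the scatter. Compound 4 is estimated at 28%, within a range from 15% to 40%.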

Compound 4, a percentage reported as inhibition, at one concentration (the size of the read-out at that concentration, not a potency): 41.3%
The estimate for compound 4 lay 13.3 percentage points below the measured number; measured number outside the range, above it.
By their numbers in this assay, from the lowest: compound 3; then compounds 1, 2 and 4 (each within the scatter of the next, the first and the last beyond it).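

In this assay the methyl that separates sec-butyl from isopropyl on this saturated chain carbon matters on its own, as a number 29.9 percentage points higher from compound 3 to compound 4 (beyond the scatter) shows, so removing it more than recovers the ground the opening step suggested was at stake. Isopropyl in place of isobutyl gives a number 7.6 percentage points higher from compound 2 to compound 4 (within the scatter) and leaves those two chains unseparated, so among the three chains shown the low number belongs to sec-butyl alone and does not extend to isobutyl. With the isopropyl chain held constant, hydrogen in place of nitro on an aromatic carbon gives a number 11.5 percentage points higher from compound 1 to compound 4 (beyond the scatter) and shows that a second place in the molecule also moves the number.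

Still open, going by these compounds, is how a straight n-butyl chain, a cyclohexyl group or a chain ending in an amine would read at the chain carbon, and whether an amine or a methoxy group on the aromatic carbon that carries nitro in compound 1 would track hydrogen or nitro. No supporting data bear on the reason for any of these steps.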